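The compounds below may be only part of what the source reports. "The series", "measured", "known", "first", "only" and "open" are said of these compounds alone.

Compound 1 `Cc1cc(NC(=O)Nc2ccccc2OC(F)(F)F)c2ccccc2n1`: > 25000 nM (a limit)
Compound 2 `Cc1cc(NC(=O)Nc2ccccc2N)c2ccccc2n1`: > 25000 nM (a limit)
Compound 3 `Cc1ccc(NC(=O)Nc2cc(C)nc3ccccc23)cc1`: > 25000 nM (a limit)

The three compounds were tested in an ADME assay on BJ cells (Homo sapiens) for cytotoxicity, with a stated time of 72 h (on this read-out lower numbers stand for an effect already at smaller amounts and higher numbers for an effect only at larger amounts of compound), and none of them gave a number. In this assay compound 2 gives > 25000 nM, which is a limit and not a measured value. Its two neighbours are also reported only as limits, so compound 2 has no readable rank among them. The evidence amounts to the limit of > 25000 nM in this assay, at which 3 of the 3 values shown sit.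

Compound 4 `Cc1cc(NC(=O)Nc2ccccc2C(C)(C)C)c2ccccc2n1` is compound 2 with one change, tert-butyl in place of amino on an aromatic carbon. Among the measured compounds shown here, two measured steps bear on this. The nearer one, with amino in place of trifluoromethoxy on an aromatic carbon, is a step that the two limits leave unreadable from compound 1 to compound 2. The other, at the group on the amide-type nitrogen, is a step that the two limits leave unreadable from compound 2 to compound 3. Neither has a size that can be carried over, and neither gives a direction. No step beyond the usual scatter is therefore expected in this assay, and compound 4 will most likely be reported as a limit too. The expected step is a number no higher from compound 2 to compound 4 (the limit leaves the size open). The estimate for compound 4 is 25000 nM, within an expected range from 12000 nM to 50000 nM.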

Compound 4, half-maximal effective concentration: 22000 nM
For compound 4 the middle estimate is 1.1-fold (0.06 log units) above the measured one; low and high end bracket the measured number.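

In this assay compound 4 gives 22000 nM, the only measured number among the compounds shown, so a group at this place, ortho to a large group, can bring the read-out to an actual value. Tert-butyl in place of amino is an at least 1.1-fold lower number from compound 2 to compound 4 (0.05 log units; that floor lies within the scatter), and tert-butyl in place of trifluoromethoxy is an at least 1.1-fold lower number from compound 1 to compound 4 (0.05 log units; that floor lies within the scatter); both are floors and not sizes, so neither change can yet be said to lie beyond the scatter. The result therefore adds one number and one lower bound on each step, while the rest of the picture remains as it was: the limit of > 25000 nM in this assay, at which 3 of the 4 values shown sit.

On these data alone, how far tert-butyl really stands from amino or trifluoromethoxy stays open, since compound 1 and compound 2 give no number, and the steps among compound 1, compound 2 and compound 3 cannot be read. The compounds shown also leave open whether a methyl group, an isopropyl group or a carboxylic acid at this place would give a number in this assay or stay at a limit.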